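A few compounds are considered here, and "the series" means these few. Any claim that something is new, unique, unknown or untested is made for them only; others in the source may bear on it.

In a functional assay on HepG2 cells (Homo sapiens) for cytotoxicity, read by MTT assay, with a stated time of 24 h (a lower number here means a stronger inhibitor, a higher number a weaker inhibitor), compound 1 `CN1C/C(=C\c2ccncc2)C(=O)/C(=C/c2ccccc2C(F)(F)F)C1` gives 3300 nM while compound 2 `O=C1/C(=C/c2ccncc2)CN(S(=O)(=O)c2ccccc2)C/C1=C\c1ccccc1C(F)(F)F` gives 7020 nM and compound 3 `Cc1ccc(S(=O)(=O)N2C/C(=C\c3ccncc3)C(=O)/C(=C/c3ccccc3C(F)(F)F)C2)cc1` gives 4640 nM on their shared core. Compound 3 stands within the scatter of both others as a 1.4-fold higher number from compound 1 to compound 3 (0.15 log units; within the scatter) and a 1.5-fold lower number from compound 2 to compound 3 (0.18 log units; within the scatter) show, and only a 2.1-fold higher number from compound 1 to compound 2 (0.33 log units; beyond the scatter) is a modest step beyond it. Compound 4 `O=C1/C(=C/c2ccncc2)CN(S(=O)(=O)c2ccc(C(F)(F)F)cc2)C/C1=C\c1ccccc1C(F)(F)F` differs from compound 3 in one place by trifluoromethyl in place of methyl on an aromatic carbon with trifluoromethyl in place of methyl on an aromatic carbon. Among the measured compounds shown here, the one measured change at that carbon was methyl in place of hydrogen with a 1.5-fold lower number from compound 2 to compound 3 (0.18 log units; within the scatter) as its size, so no shift beyond the scatter is expected. The estimate therefore means a 1.1-fold higher number from compound 3 to compound 4 (0.03 log units; within the scatter) as the expected step. Compound 4 is estimated at 5000 nM within a range from 2500 nM to 10000 nM in this assay once measured.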

Compound 4, half-maximal inhibitory concentration: 3240 nM
For compound 4 the middle estimate is 1.5-fold (0.19 log units) above the measured one; measured number inside the range.
By their numbers in this assay, from the lowest: compounds 4, 1, 3 and 2 (each within the scatter of the next, the first and the last beyond it).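

Putting trifluoromethyl in place of methyl on this aromatic carbon gives a 1.4-fold lower number from compound 3 to compound 4 (0.16 log units; within the scatter) in this assay so the larger group, with four heavy atoms against one, leaves the number within reach of methyl. Set against hydrogen on the same carbon, trifluoromethyl gives a 2.2-fold lower number from compound 2 to compound 4 (0.34 log units; beyond the scatter) and this modest step passes the scatter, which the step from hydrogen to methyl did not.

Going by these compounds, whether an amine, a carboxylic acid or a methoxy group on this carbon would fit the same picture stays open. No measurement at hand says why these steps have the sizes they do.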